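Swapping the Sulfonyl Aryl Group: Compound 1 to Compound 4

This account rests on a few compounds, and the source may have more. Where it says the series, first, only, none or still open, it means among the compounds named here.

Measured so far:
compound 1 `COc1cccc(-c2c(S(=O)(=O)c3ccc(OC)c(Cl)c3)cnc3cc(F)ccc23)c1` gives 1.71 mL/min
compound 2 `COc1cccc(-c2c(S(=O)(=O)c3cc(Cl)cc(Cl)c3)cnc3c(F)cccc23)c1` gives 2.31 mL/min
compound 3 `O=S(=O)(c1ccc(F)c(F)c1)c1cnc2cc(F)ccc2c1-c1ccc(Cl)cc1` gives 0.01 mL/min

In an ADME assay on microsomes from liver (Homo sapiens) for metabolic stability, tested at 2.5 uM (a higher number here means faster removal of the compound, a lower number slower removal), compound 1 stands second highest of the three numbers. Compound 2 lies nearest, and the gap between the two is within the usual scatter, so they cannot be told apart. Compound 3 lies far lower, beyond the scatter.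

Compound 4 `COc1cccc(-c2c(S(=O)(=O)c3ccc(C)c(C)c3)cnc3cc(F)ccc23)c1` is not yet measured. Relative to compound 1 its change is 3,4-dimethylphenyl in place of 3-chloro-4-methoxyphenyl on a sulfonyl sulfur. Going by the values given here, no measured pair shows this same change, so the expected step in this assay rests on compound 1 alone, and is expected to be small, within the scatter, if anything slightly upward.

For compound 4 the expected value in this assay is 2.4 mL/min, ranging from 1 mL/min to 6 mL/min, an expected step of a 1.4-fold higher number from compound 1 to compound 4 (0.15 log units; within the scatter).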

Compound 4, intrinsic clearance in a liver preparation (reported as CLH), per the amount of preparation that the assay uses: 8.78 mL/min
Compound 4: middle estimate off by 3.7-fold (0.56 log units), on the low side; the measured number lies above the stated range.
By their numbers in this assay, from the lowest: compound 3; then compounds 1 and 2 (each within the scatter of the next); then compound 4.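

In this assay, 3,4-dimethylphenyl in place of 3-chloro-4-methoxyphenyl on a sulfonyl sulfur gives a 5.1-fold higher number from compound 1 to compound 4 (0.71 log units; beyond the scatter) and so shows that this change alone, with the rest of compound 1 kept, can move the number beyond the scatter. The earlier compounds shown here differed in more than one place and could not show this. Nothing measured here explains the size of this step.

Going by these compounds, the chloro and methoxy groups leave together, and which of them matters stays open. On these data alone, how an aryl group bearing an amine or a carboxylic acid would behave at this position also stays open.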